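This account rests on a few compounds, and the source may have more. Where it says the series, first, only, none or still open, it means among the compounds named here.

Going by the values given here, compound 2 `O=C(O)/C=C/C(=O)c1ccccc1` gives in a functional assay on K562 cells (Homo sapiens) for inhibition, read by MTT assay, with a stated time of 72 h (a lower number here means a stronger inhibitor, a higher number a weaker inhibitor), a value of 30200 nM, the highest of the two numbers measured so far; its nearest neighbour, compound 1 `CC(C)(C)c1ccc(C(=O)/C=C/C(=O)O)cc1`, gives 4330 nM. Among the compounds with values here, the single measured step runs a 7.0-fold higher number from compound 1 to compound 2 (0.84 log units; beyond the scatter). Compound 3 `CCCCc1ccc(C(=O)/C=C/C(=O)O)cc1` differs from compound 2 by butyl in place of hydrogen on an aromatic carbon, a butyl chain entering at an aromatic carbon as the tert-butyl of compound 1 does. Within the data shown here, that step is the only one bearing on the change, so a lowering of similar size is expected in this assay, a 6.0-fold lower number from compound 2 to compound 3 (0.78 log units; beyond the scatter). Compound 3 is therefore estimated at 5000 nM, within 2000 nM to 15000 nM.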

Compound 3, half-maximal inhibitory concentration: 4950 nM
The estimate for compound 3 lay 1.0-fold (0.00 log units) above the measured number, and the stated range covers the measured number.
By their numbers in this assay, from the lowest: compounds 1 and 3 (each within the scatter of the next); then compound 2.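

In this assay, butyl on this aromatic carbon, para to a group of 7 heavy atoms, lowers the number as tert-butyl does (a 6.1-fold lower number from compound 2 to compound 3 (0.79 log units; beyond the scatter)). The two groups cannot be told apart here (a 1.1-fold higher number from compound 1 to compound 3 (0.06 log units; within the scatter)), so the lowering is not tied to tert-butyl alone. Nothing available explains this result. The compounds shown leave open whether a longer chain, a methyl group or an amine on this carbon would lower the number as well. They also leave open whether butyl would do so on another carbon of the ring.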